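The source may report more compounds than this note shows. Statements on the series, on what has been measured and on what is new or still open speak of the compounds shown alone.

Working notes on the series. Compound 1 `CC(C)C[C@H](NC(=O)[C@@H](NS(=O)(=O)c1ccc(/N=N/c2ccccc2)cc1)C(C)C)C(=O)C(N)=O` gives 16 nM in an assay on cells (Erythrocyte) for inhibition of Calpain-1 catalytic subunit (Sus scrofa), using a Dixon plot; on this read-out higher numbers stand for weaker inhibition and lower numbers for stronger inhibition. Compound 2 `CC(C)C[C@@H](C=O)NC(=O)[C@@H](NS(=O)(=O)c1ccc(/C=C/c2ccccc2)cc1)C(C)C` gives 14 nM in this assay; that is the lowest of the two numbers, with compound 1 next to it within the scatter. Compound 3 `CC(C)C[C@H](NC(=O)[C@@H](NS(=O)(=O)c1ccc(/C=C/c2ccccc2)cc1)C(C)C)C(=O)C(N)=O` is not yet measured; it carries carbamoyl in place of hydrogen on a carbonyl carbon. Within the data shown here, no step between two measured compounds isolates this change, but compound 1 already carries the carbamoylcarbonyl end and gives 16 nM, so no step beyond the scatter is expected from compound 2, a 1.3-fold higher number from compound 2 to compound 3 (0.11 log units; within the scatter). Compound 3 is expected to give 18 nM, in the range 8 nM to 45 nM.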

Compound 3, inhibition constant: 9 nM
Beside the measured number, compound 3's estimate is 2.0-fold (0.30 log units) above it; low and high end bracket the measured number.
By their numbers in this assay, from the lowest: compounds 3, 2 and 1 (each within the scatter of the next).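

In this assay, carbamoyl in place of hydrogen on a carbonyl carbon can now be read directly on the shared core (a 1.6-fold lower number from compound 2 to compound 3 (0.19 log units; within the scatter)), and this step leaves formyl and carbamoylcarbonyl untold apart at this position. The exchange of one group of 8 heavy atoms for another on an aromatic carbon also stays within the scatter (a 1.8-fold lower number from compound 1 to compound 3 (0.25 log units; within the scatter)). Nothing available bears on the reason for either reading. From the compounds shown here alone, whether a carboxylic acid or a methyl ketone in place of the carbamoyl group on this carbonyl carbon would also stay within the scatter remains open.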